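The compounds below may be only part of what the source reports. "The series", "measured", "known", "first", "only" and "open" are said of these compounds alone.

Compound 1 `O=C(Nc1cccc(O)c1)c1nccc2ccccc12`: > 10000 nM
Compound 2 `O=C(Nc1cccc(C(F)(F)F)c1)c1nccc2ccccc12`: > 10000 nM
Compound 3 `O=C(Nc1ccc(C(F)(F)F)cc1)C1NCCc2ccccc21`: 4220 nM

Of the compounds shown here, three have so far been tested in a functional assay on NUGC-3 cells (Homo sapiens) for inhibition, read by sulforhodamine B assay, with a stated time of 48 h; on this read-out lower numbers stand for stronger inhibition of growth and higher numbers for weaker inhibition of growth. For compound 1 the value > 10000 nM is a limit of the assay and not a number. For compound 2 the value > 10000 nM is likewise a limit. Compound 3 is the only one of the three that returns a number in this assay, 4220 nM; how its core differs from the core of compound 2 is not broken down here.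

Compound 2 and compound 1 differ in one place: hydroxy in place of trifluoromethyl on an aromatic carbon. The step that the two limits leave unreadable from compound 2 to compound 1 is unreadable because both compounds sit at the limit of > 10000 nM in this assay, at which 2 of the 3 values shown sit.

Compound 4 `O=C(Nc1ccc(O)cc1)C1NCCc2ccccc21` has not yet been measured in this assay. It differs from compound 3 in one place: hydroxy in place of trifluoromethyl on an aromatic carbon. This is the same kind of change as that from compound 2 to compound 1, but not the same: in compound 1 the hydroxy is meta to a large group, in compound 4 it is para to a large group. The earlier step gives no size to lean on. The step of a 1.7-fold higher number from compound 3 to compound 4 (0.22 log units; within the scatter) is therefore an expectation resting on compound 3 alone with its value 4220 nM. The estimate is held wide, and the measurement of compound 4 may well return no number at all. Compound 4 is expected to come in around 7000 nM, between 2000 nM and 25000 nM.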

Compound 4, concentration for 50% growth inhibition: 4370 nM
For compound 4 the middle estimate is 1.6-fold (0.20 log units) above the measured one; the range from low to high includes it.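

In this assay, hydroxy in place of trifluoromethyl on an aromatic carbon, para to a large group, gives a 1.0-fold higher number from compound 3 to compound 4 (0.02 log units; within the scatter), so on the core of compound 3 this change leaves the read-out within the scatter. On the core of compound 1 the same kind of change has no readable size, since compound 2 and compound 1 both stand at a limit of the assay and not at a number: the limit of > 10000 nM in this assay, at which 2 of the 4 values shown sit. The result therefore shows that the two groups can be exchanged at this one place on one core with no change beyond the scatter, but it does not show that this holds on another core, and the two pairs also differ in where the group sits on the ring.

The compounds shown leave open whether an amine, a carboxylic acid or a longer chain at the same place on the core of compound 3 would shift the value beyond the scatter, since only trifluoromethyl and hydroxy appear there. They also leave open what the core alone contributes, as no pair shown carries the same group at the same place on the two cores.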